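The source may report more compounds than this note shows. Statements on the series, on what has been measured and on what is new or still open speak of the compounds shown alone.

In a functional assay on MIA PaCa-2 cells (Homo sapiens) for inhibition, read by MTT assay, with a stated time of 3 days (on this read-out higher numbers stand for weaker inhibition and lower numbers for stronger inhibition), compound 1 `CCN(CC)S(=O)(=O)c1ccc(S(=O)(=O)N2CCC[C@@H](C(=O)N[C@H]3CC[C@H](OC)CC3)C2)cc1` gives > 10000 nM as a limit, not a number. Compound 2 `CCN(CC)S(=O)(=O)c1ccc(S(=O)(=O)N2CCC[C@@H](C(=O)N3CCOCC3)C2)cc1` gives > 10000 nM as a limit too. Compound 3 `CCN(CC)S(=O)(=O)c1ccc(S(=O)(=O)N2CCC[C@@H](C(=O)N3CCC(C(F)(F)F)CC3)C2)cc1` gives > 10000 nM as a limit too. The three thus stand together at the limit of > 10000 nM in this assay, at which 3 of the 3 values shown sit, and offer no number. Compound 4 `CCN(CC)S(=O)(=O)c1ccc(S(=O)(=O)N2CCC[C@@H](C(=O)N3CCC(COC)CC3)C2)cc1` carries 4-(methoxymethyl)piperidin-1-yl in place of (4-methoxycyclohexyl)amino on a carbonyl carbon, counted as 4-(methoxymethyl)piperidin-1-yl in place of (4-methoxycyclohexyl)amino on a carbonyl carbon in full. The steps bearing on this change are a step that the two limits leave unreadable from compound 1 to compound 2 and a step that the two limits leave unreadable from compound 1 to compound 3 and a step that the two limits leave unreadable from compound 2 to compound 3 and none has a readable size. From compound 1 at its limit of > 10000 nM no change beyond the scatter is expected in this assay and the estimated move is a step that the limit leaves unreadable from compound 1 to compound 4 at most. Compound 4 is expected near 15000 nM within an estimated range of 7000 nM to 30000 nM and will probably be reported only as a limit.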

Compound 4, half-maximal inhibitory concentration: > 10000 nM
Compound 4: only a limit was reported (the forecaster's own chance of this, stated with the estimate: 85%); the middle value is on the limit's open side.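

Compound 4 is reported only as a limit, as are compound 1, compound 2 and compound 3, so no step among them can be read: the limit of > 10000 nM in this assay, at which 4 of the 4 values shown sit.

The compounds shown leave open what actual number any of the four would give in this assay.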